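A Phenylpiperazine in Place of the Pentyl Chain

This account rests on a few compounds, and the source may have more. Where it says the series, first, only, none or still open, it means among the compounds named here.

In a functional assay on the whole organism for antagonist activity, with Mus musculus as the target (on this read-out higher numbers stand for an effect only at larger amounts of compound and lower numbers for an effect already at smaller amounts), compound 1 `CC(C)NCC(=O)NCC(=O)N(C)c1ccc(Cl)cc1C(=O)c1ccccc1Cl` gives 1 mg/kg, and compound 2 `CCCCCCC(=O)NCC(=O)N(C)c1ccc(Cl)cc1C(=O)c1ccccc1Cl` gives 1.9 mg/kg. Among the compounds with values here, these two numbers lie within the usual scatter of each other, so compound 2 cannot be ranked against its only neighbour. Compound 3 `CN(C(=O)CNC(=O)CN1CCN(c2ccccc2)CC1)c1ccc(Cl)cc1C(=O)c1ccccc1Cl` keeps the shared core and changes one group: 4-phenylpiperazin-1-yl in place of pentyl on a saturated chain carbon bound to a carbonyl carbon. Here 4-phenylpiperazin-1-yl takes the place of pentyl on a saturated chain carbon bound to a carbonyl carbon. Within the data shown here, only one measured step bears on this place, a 1.9-fold higher number from compound 1 to compound 2 (0.28 log units; within the scatter), where pentyl took the place of isopropylamino. Neither compound 1 nor compound 2 carries a ring here, so this evidence is thin. The expectation in this assay is therefore no change beyond the scatter, with a wide margin. The expected step is a 1.3-fold lower number from compound 2 to compound 3 (0.10 log units; within the scatter). Compound 3 is estimated at 1.5 mg/kg, within an expected range from 0.5 mg/kg to 5 mg/kg.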

Compound 3, dose for half-maximal effect: 75 mg/kg
Estimate against measurement, compound 3: 50-fold (1.70 log units) below; the whole stated range lies below it.
By their numbers in this assay, from the lowest: compounds 1 and 2 (each within the scatter of the next); then compound 3.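

The two earlier compounds suggested that this position accepts quite different groups, yet it does not accept every group. In this assay there is a 39-fold higher number from compound 2 to compound 3 (1.60 log units; beyond the scatter), and against the other neighbour there is a 75-fold higher number from compound 1 to compound 3 (1.88 log units; beyond the scatter), so much more compound is needed for the same effect once 4-phenylpiperazin-1-yl sits on the saturated chain carbon bound to a carbonyl carbon. Nothing measured here explains why this step is so large.

The compounds shown leave open which part of 4-phenylpiperazin-1-yl goes with this step, the non-aromatic ring with its two nitrogens or the aromatic ring of carbon attached to it. A plain piperazin-1-yl without the phenyl, or a benzylamino group in the same place, would help to separate the two.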